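Compound 2 to compound 3: pyridin-2-yl for methyl

A few compounds are considered here, and "the series" means these few. Any claim that something is new, unique, unknown or untested is made for them only; others in the source may bear on it.

Measured in an ADME assay on microsomes from liver (Homo sapiens) for metabolic stability, read by LC-MS, with a stated time of 10 min; on this read-out higher numbers stand for a more stable compound and lower numbers for a less stable compound:
Compound 1 `CN(C[C@H]1Cc2c(cccc2N2CCN(c3cccc(C(F)(F)F)c3)CC2)CN1)[C@H]1CCCc2cccnc21`: 90.3%
Compound 2 `CN1CCN(c2cccc3c2C[C@H](CN(C)[C@H]2CCCc4cccnc42)NC3)CC1`: 75.8%

Compound 2 stands lowest of the two, with the gap to compound 1 beyond the scatter. Compound 3 `CN(C[C@H]1Cc2c(cccc2N2CCN(c3ccccn3)CC2)CN1)[C@H]1CCCc2cccnc21` carries the change pyridin-2-yl in place of methyl on an amine nitrogen in a ring. For the measured compounds named here, one measured step bears on it: a number 14.5 percentage points lower from compound 1 to compound 2 (beyond the scatter), a modest one, with methyl in place of 3-(trifluoromethyl)phenyl at that nitrogen. Read in reverse, it points to a rise of similar or smaller size in this assay, although pyridin-2-yl itself is unmeasured. The expected step is a number 9.2 percentage points higher from compound 2 to compound 3 (within the scatter). The estimate for compound 3 is 85%, with an expected range of 73% to 96%.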

Compound 3, percent of the compound remaining: 27.4%
Compound 3: the middle estimate sits 57.6 percentage points above what was measured, outside the stated range (below it).
By their numbers in this assay, from the lowest: compound 3; then compound 2; then compound 1.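

At this amine nitrogen, pyridin-2-yl in place of methyl gives a number 48.4 percentage points lower from compound 2 to compound 3 (beyond the scatter) in this assay, so an aromatic ring here does not by itself go with a higher number. Pyridin-2-yl in place of 3-(trifluoromethyl)phenyl gives a number 62.9 percentage points lower from compound 1 to compound 3 (beyond the scatter) and shows that the outcome at this position depends on which aromatic ring enters. Nothing at hand gives a cause for this loss.

Still open, on these data alone, is whether the ring nitrogen of pyridin-2-yl or the absence of trifluoromethyl accounts for the low number of compound 3. Plain phenyl or pyridin-3-yl at this nitrogen would separate those two changes.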